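Stereo inversion at the pyrrolidine carbon in the fluoro series

The source may hold more compounds than are shown below. What is called first, only, known or untested is meant among the compounds shown, and "the series" means these compounds.

Compound 3 `Fc1ccc2cc(C[C@H]3CCCN3)[nH]c2n1` gives 316 nM in an assay on membranes from brain for displacement of a labelled ligand from Neuronal acetylcholine receptor; alpha4/beta2 (Rattus norvegicus) (a higher number here means a weaker inhibitor, a lower number a stronger inhibitor), the lowest number among the three measured; compound 1 `c1cnc2[nH]c(C[C@@H]3CCCN3)cc2c1` gives 2750 nM and compound 2 `Clc1ccc2cc(C[C@@H]3CCCN3)[nH]c2n1` gives 3720 nM, both beyond the scatter above it. For the measured compounds named here, the only measured step, a 1.4-fold higher number from compound 1 to compound 2 (0.13 log units; within the scatter), concerns a halogen on the aromatic ring and does not bear on a change of configuration. Compound 4 `Fc1ccc2cc(C[C@@H]3CCCN3)[nH]c2n1` differs from compound 3 in that (the two compounds have the same atoms and bonds and differ only in configuration as drawn: 1 of 1 stereo elements differ; a stereocentre at a saturated ring carbon is drawn R in compound 3 and S in compound 4), which brings it to the configuration drawn for compound 1 and compound 2. Going by the values given here, no step tests this inversion directly; the compounds sharing the configuration of compound 4 sit well above compound 3. Compound 4 is therefore expected to move by a 4.7-fold higher number from compound 3 to compound 4 (0.68 log units; beyond the scatter), toward weaker binding, with an estimated 1500 nM and a range of 250 nM to 7000 nM.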

Compound 4, inhibition constant: 2000 nM
Estimate against measurement, compound 4: 1.3-fold (0.12 log units) below; measured number inside the range.
By their numbers in this assay, from the lowest: compound 3; then compounds 4, 1 and 2 (each within the scatter of the next).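

In this assay, for the compounds shown here, configuration at the saturated ring carbon is the one change here that moves the number beyond the scatter: a 6.3-fold higher number from compound 3 to compound 4 (0.80 log units; beyond the scatter). With the stereocentre drawn S, the aromatic substituent does not separate the compounds: a 1.9-fold lower number from compound 2 to compound 4 (0.27 log units; within the scatter), and a 1.4-fold lower number from compound 1 to compound 4 (0.14 log units; within the scatter). The gap can be assigned to the stereocentre alone, because of this: the fact that compounds 3 and 4 differ only in the configuration as drawn

On these data alone, whether the R configuration keeps such a gap with chloro or hydrogen on the aromatic carbon remains open. So does the effect of a methoxy group or an amine at that carbon.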